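The source may report more compounds than this note shows. Statements on the series, on what has been measured and on what is new or still open speak of the compounds shown alone.

Measured so far in a physicochemical assay for solubility, at pH 7; on this read-out lower numbers stand for lower solubility and higher numbers for higher solubility:
Compound 1 `CC(C)(C)C(=O)N1Cc2c(NC(=O)c3cccnc3)n[nH]c2C1(C)C`: 207000 nM
Compound 2 `CN1CCC(C(=O)N2Cc3c(NC(=O)c4cccs4)n[nH]c3C2(C)C)CC1`: 155000 nM
Compound 3 `CN1CCC(C(=O)N2Cc3c(NC(=O)c4ccc(C(F)(F)F)cc4)n[nH]c3C2(C)C)CC1`: 191000 nM

Compound 1, at 207000 nM, stands level with compound 2 and compound 3. All three values lie within the scatter of one another, so no order can be read among them.

The compound still to be measured is compound 4 `CC(C)(C)C(=O)N1Cc2c(NC(=O)c3ccncc3)n[nH]c2C1(C)C`. It has the same atoms as compound 1, joined differently: pyridin-4-yl in place of pyridin-3-yl on a carbonyl carbon. In words, pyridin-4-yl stands in place of pyridin-3-yl on a carbonyl carbon, and the rest of compound 1 is kept.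

Among the compounds with values here, no measured step makes this exchange. Within the data shown here, the only step available is a 1.2-fold higher number from compound 2 to compound 3 (0.09 log units; within the scatter), where 4-(trifluoromethyl)phenyl takes the place of thiophen-2-yl, also on a carbonyl carbon. That is a different exchange and a single example, so it is thin evidence, but it stays within the scatter. Nothing in these data points to a direction for the new change, and no movement beyond the scatter is expected in this assay. The expected step is a 1.1-fold lower number from compound 1 to compound 4 (0.04 log units; within the scatter), which would leave the value within the scatter. Compound 4 is estimated at 190000 nM, with an expected range from 95000 nM to 320000 nM.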

Compound 4, solubility: 205000 nM
Compound 4: middle estimate off by 1.1-fold (0.03 log units), on the low side; low and high end bracket the measured number.
By their numbers in this assay, from the lowest: compounds 2, 3, 4 and 1 (each within the scatter of the next).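

In this assay, within the data shown here, pyridin-4-yl in place of pyridin-3-yl on a carbonyl carbon gives a 1.0-fold lower number from compound 1 to compound 4 (0.00 log units; within the scatter), which is the first direct reading of this exchange and shows that it leaves the number within the scatter. Among these compounds, until now, the only step at this kind of position was a 1.2-fold higher number from compound 2 to compound 3 (0.09 log units; within the scatter), a different exchange on a different amide group, so the new step adds a second case within the scatter, this time between two groups with identical counts under the comparison of their structures. Nothing measured alongside these numbers bears on why the exchange behaves this way, and so the result stands as an observation without an explanation.

The compounds shown leave open whether a group of another kind on this carbonyl carbon, such as a ring carrying an amine or a carboxylic acid, would take the number in this assay beyond the scatter. All four numbers also lie within the scatter of their neighbours, so they give no indication of how far this read-out can move among compounds that share this core.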